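Vinyl for Allyl: Expected Tolerability of Compound 3

This account rests on a few compounds, and the source may have more. Where it says the series, first, only, none or still open, it means among the compounds named here.

Of the compounds shown here, two have been measured so far. Compound 1 `C=CCNC(=O)[C@@H](NC(=O)[C@@](O)(CCCN(Cc1ccc(Br)cc1)NC(=O)[C@@H](NC(=O)OC)C(C)(C)C)Cc1ccc(CC=C)cc1)C(C)(C)C` and compound 2 `COC(=O)N[C@H](C(=O)NN(CCC[C@@]1(O)Cc2ccc(cc2)/C=C\CNC(=O)[C@H](C(C)(C)C)NC1=O)Cc1ccc(Br)cc1)C(C)(C)C` were both tested in an ADME assay on MT4 cells (Homo sapiens) for cytotoxicity, read by XTT assay, with a stated time of 5 days; a lower number here means that less compound is tolerated, a higher number that more compound is tolerated. Compound 2 gives 40000 nM in this assay. For compound 1 this assay reports > 50000 nM, which is a limit of the measurement and not a number. Among the measured compounds shown here, compound 1 thus stands at the limit of > 50000 nM in this assay, at which 1 of the 2 values shown sits, and only a range is known for it, so no measured step between it and another compound can be drawn.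

Compound 3 `C=CCNC(=O)[C@@H](NC(=O)[C@@](O)(CCCN(Cc1ccc(Br)cc1)NC(=O)[C@@H](NC(=O)OC)C(C)(C)C)Cc1ccc(C=C)cc1)C(C)(C)C` has not yet been measured. It differs from compound 1 in a single place: vinyl in place of allyl on an aromatic carbon. For the measured compounds named here, no measured pair shows what this exchange does in this assay, so the expectation rests on compound 1 alone. A step of a number no higher from compound 1 to compound 3 (the limit leaves the size open) is expected, none beyond the usual scatter, and the outcome may well again be reported only as a limit. Compound 3 is estimated at 50000 nM, with a range from 25000 nM to 100000 nM.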

Compound 3, half-maximal cytotoxic concentration: 44000 nM
The estimate for compound 3 lay 1.1-fold (0.06 log units) above the measured number, and the stated range covers the measured number.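

Replacing the 4-allylphenyl group with 4-vinylphenyl gives the first view of how this position responds to a change in this assay, with an at least 1.1-fold lower number from compound 1 to compound 3 (0.05 log units; that floor lies within the scatter). Shortening the group attached to the aromatic ring by one carbon therefore brings no change beyond the usual scatter that can be shown here, and compound 3 gives 44000 nM, a real number for this position rather than a limit. Compound 1 is reported only as a limit, so the true size of the step cannot be read, and a larger drop remains possible: the limit of > 50000 nM in this assay, at which 1 of the 3 values shown sits.

This exchange is seen in just one pair of compounds on one shared core, so it says nothing yet about how the same change would behave on another core or in another assay. From the compounds shown here alone, it also remains open how this assay would respond if the same aromatic carbon carried a group of a different kind, such as an ethyl group without a double bond, a longer chain such as butyl, an amine or a carboxylic acid.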